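Ring expansion on the thiocarbamate of an adenosine nucleoside

The source may report more compounds than this note shows. Statements on the series, on what has been measured and on what is new or still open speak of the compounds shown alone.

Compound 2 `O[C@@H]1[C@@H](CO/C(S)=N/C2CCC2)OC(n2cnc3c(NC4CCOC4)ncnc32)[C@@H]1O` gives 148 nM in an assay on DDT1 cells (Cricetulus griseus) for binding affinity to adenosine receptor A1 (Homo sapiens), read by radioligand binding (on this read-out lower numbers stand for stronger inhibition and higher numbers for weaker inhibition), the lowest of the two numbers shown; its nearest neighbour is compound 1 `CCCNC(=O)OC[C@H]1OC(n2cnc3c(NC4CCOC4)ncnc32)[C@H](O)[C@@H]1O`, which gives 235 nM in this assay. Among the measured compounds shown here, the only measured step, a 1.6-fold lower number from compound 1 to compound 2 (0.20 log units; within the scatter), is within the scatter and concerns a different change. Compound 3 `O[C@@H]1[C@@H](CO/C(S)=N/C2CCCC2)OC(n2cnc3c(NC4CCOC4)ncnc32)[C@@H]1O` differs from compound 2 by cyclopentyl in place of cyclobutyl on a double-bonded nitrogen. For the measured compounds named here, no measured step bears on this change, so the expected step of a 1.1-fold lower number from compound 2 to compound 3 (0.06 log units; within the scatter) is none beyond the scatter. Compound 3 is estimated at 130 nM in this assay, in the range 50 nM to 350 nM.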

Compound 3, inhibition constant: 72 nM
Compound 3: the middle estimate sits 1.8-fold (0.26 log units) above what was measured; measured number inside the range.
By their numbers in this assay, from the lowest: compound 3; then compounds 2 and 1 (each within the scatter of the next).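

In this assay, among the compounds shown here, cyclopentyl in place of cyclobutyl on a double-bonded nitrogen gives a 2.1-fold lower number from compound 2 to compound 3 (0.31 log units; beyond the scatter), the first step at this place and one that lies beyond the scatter. Measured against the open-chain group on an oxygen on a saturated carbon, the cyclopentyl compound also gives a step beyond the scatter, a 3.3-fold lower number from compound 1 to compound 3 (0.51 log units; beyond the scatter), whereas the cyclobutyl compound stayed within it. Nothing measured accounts for this gain. Only two ring sizes are shown at this place. Going by these compounds, whether a cyclohexyl ring would extend the step, or an open pentyl chain would match it, remains open.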